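This account rests on a few compounds, and the source may have more. Where it says the series, first, only, none or still open, it means among the compounds named here.

In an ADME assay on Vero cells (Chlorocebus sabaeus) for antiproliferative activity, read by MTT assay; a higher number here means a weaker inhibitor, a lower number a stronger inhibitor:
Compound 1 `c1ccc2c(c1)ccn2-c1nc(N2CCNCC2)nc2ccccc12`: 8.9 ug/mL
Compound 2 `CN1CCN(c2nc(-n3ccc4ccccc43)c3ccccc3n2)CC1`: 22.3 ug/mL

Of these two measured compounds, compound 2 has the higher number, 22.3 ug/mL, which makes it the weaker inhibitor of the pair. The next compound to be measured is compound 3 `c1ccc(N2CCN(c3nc(-n4ccc5ccccc54)c4ccccc4n3)CC2)nc1`. It keeps the shared core but carries pyridin-2-yl in place of methyl on an amine nitrogen in a ring. Going by the values given here, the only measured step that bears on this change is a 2.5-fold higher number from compound 1 to compound 2 (0.40 log units; beyond the scatter). That step is modest and swaps methyl for hydrogen, with no ring entering, so it gives no direction for a change to pyridin-2-yl. No step beyond the scatter is therefore expected in this assay. The estimated change is a 1.2-fold lower number from compound 2 to compound 3 (0.07 log units; within the scatter). For compound 3 the estimated value is 19 ug/mL, with an expected range from 6 ug/mL to 60 ug/mL.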

Compound 3, half-maximal inhibitory concentration: 50 ug/mL
Compound 3: the middle estimate sits 2.6-fold (0.42 log units) below what was measured; low and high end bracket the measured number.
By their numbers in this assay, from the lowest: compound 1; then compound 2; then compound 3.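

In this assay, the earlier step showed only that a single methyl on this amine nitrogen of the six-membered non-aromatic ring goes with a weaker inhibitor; a whole aromatic ring in place of that methyl weakens it further, with a 2.2-fold higher number from compound 2 to compound 3 (0.35 log units; beyond the scatter). Set against the compound with only hydrogen on this nitrogen, the change gives a 5.6-fold higher number from compound 1 to compound 3 (0.75 log units; beyond the scatter), so hydrogen, methyl and pyridin-2-yl now form a series in which both replacements for hydrogen give a weaker inhibitor, and compound 3 is the weakest of the three. No measurement shown gives a reason for this loss.

Still open, from the compounds shown here alone, is whether any group on this nitrogen would raise the number, or only these two. A phenyl ring, with no ring nitrogen, or an acetyl group in the same place could help to settle that.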